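Replacing the bromine at the chain end

The source may report more compounds than this note shows. Statements on the series, on what has been measured and on what is new or still open speak of the compounds shown alone.

In a functional assay on A549 cells (Homo sapiens) for antiproliferative activity, read by MTT assay, with a stated time of 48 h (on this read-out lower numbers stand for stronger inhibition and higher numbers for weaker inhibition), compound 1 (`COc1ccc(N(C)c2ccnc(Cl)n2)cc1`) gives 611 nM, compound 2 (`COc1ccc(N(C)c2ccnc(Cl)n2)cc1[N+](=O)[O-]`) gives 3780 nM and compound 3 (`COc1ccc(N(C)c2ccnc(Cl)n2)cc1OCCCBr`) gives 862 nM. Compound 3 therefore stands with the first of these, at a 1.4-fold higher number from compound 1 to compound 3 (0.15 log units; within the scatter), and apart from the nitro compound, at a 4.4-fold lower number from compound 2 to compound 3 (0.64 log units; beyond the scatter).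

The next compound is compound 4 (`COc1ccc(N(C)c2ccnc(Cl)n2)cc1OCCCC[Se]C#N`), and the change is a group of 4 heavy atoms (2 carbon, 1 nitrogen, 1 selenium; no ring) in place of one bromine atom, on a saturated chain carbon, three bonds along the chain from an oxygen on an aromatic ring. Among the measured compounds shown here, no measured step alters this chain end, so the evidence is indirect. The nearest guide is a 1.4-fold higher number from compound 1 to compound 3 (0.15 log units; within the scatter), which shows that adding the 3-bromopropoxy chain left the value within the scatter. The larger step, a 6.2-fold higher number from compound 1 to compound 2 (0.79 log units; beyond the scatter), concerns a nitro group and says little about this change.

A modest move towards a lower number in this assay is expected, held with low confidence, and a result within the scatter of compound 3 would be no surprise. The expected step is a 2.2-fold lower number from compound 3 to compound 4 (0.33 log units; beyond the scatter). Compound 4 is estimated at 400 nM, with an expected range of 90 nM to 1500 nM.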

Compound 4, half-maximal inhibitory concentration: > 10000 nM
Compound 4 ended at the assay's limit; the forecaster's own chance of this, stated with the estimate: 3%; middle value at least 25-fold (1.39 log units) from the limit.
By their numbers in this assay, from the lowest: compounds 1 and 3 (each within the scatter of the next); then compound 2. At a limit, above all of these: compound 4.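

The value of compound 4 in this assay is a limit of the assay and not a number: the limit of > 10000 nM in this assay, at which 1 of the 4 values shown sits.

The chain end is not a silent position: putting the selenium-bearing group in place of bromo gives an at least 11-fold higher number from compound 3 to compound 4 (1.06 log units; beyond the scatter), although the 3-bromopropoxy chain itself stayed within the scatter of compound 1. The other steps are an at least 16-fold higher number from compound 1 to compound 4 (1.21 log units; beyond the scatter) and an at least 2.6-fold higher number from compound 2 to compound 4 (0.42 log units; beyond the scatter), so in this set a change on a saturated chain carbon takes the value past that of the nitro group on an aromatic carbon.

Whether this weakening follows the selenium, the triple bond or the whole group cannot be told from compound 4 alone. A plain nitrile, a thiocyanate or an amine at the chain end, or a longer chain carrying the same group, would separate these possibilities.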